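A few compounds are considered here, and "the series" means these few. Any claim that something is new, unique, unknown or untested is made for them only; others in the source may bear on it.

Measured compounds:
- compound 1 `CC(C)N1CCN(S(=O)(=O)CCCN2CCC(CNC(=O)c3cccc4c3OCCO4)CC2)CC1`: 0.0316 nM
- compound 2 `O=C(NCC1CCN(CCCS(=O)(=O)N2CCNCC2)CC1)c1cccc2c1OCCO2`: 0.159 nM

In an assay on isolated protein for inhibition of 5-hydroxytryptamine receptor 4 (Homo sapiens) (on this read-out lower numbers stand for stronger inhibition and higher numbers for weaker inhibition), compound 1 gives 0.0316 nM and compound 2 gives 0.159 nM. For the measured compounds named here, compound 2 thus stands at the higher of the two numbers seen in this assay; its only neighbour is compound 1, and the gap between them is a 5.0-fold higher number from compound 1 to compound 2 (0.70 log units; beyond the scatter), a change made by putting hydrogen in place of isopropyl on an amine nitrogen in a ring.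

Compound 3 `CCCS(=O)(=O)N1CCN(S(=O)(=O)CCCN2CCC(CNC(=O)c3cccc4c3OCCO4)CC2)CC1` is not yet measured. It differs from compound 2 by propylsulfonyl in place of hydrogen on an amine nitrogen in a ring. Going by the values given here, the one step that bears on this position is the one from compound 1 to compound 2, a 5.0-fold higher number from compound 1 to compound 2 (0.70 log units; beyond the scatter), which shows that an unsubstituted ring nitrogen gives the weaker number of the pair and that a group on that nitrogen goes with the stronger one. Propylsulfonyl is not isopropyl, so the step is only a guide, and the expected direction is toward a lower number with a wide range. For compound 3 the expected step is a 2.0-fold lower number from compound 2 to compound 3 (0.30 log units; within the scatter). Compound 3 is therefore estimated at 0.08 nM, with a range from 0.02 nM to 0.32 nM.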

Compound 3, inhibition constant: 0.1 nM
For compound 3 the middle estimate is 1.3-fold (0.10 log units) below the measured one, within the range that was stated.
By their numbers in this assay, from the lowest: compound 1; then compounds 3 and 2 (each within the scatter of the next).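

In this assay, a 1.6-fold lower number from compound 2 to compound 3 (0.20 log units; within the scatter), so on this read-out propylsulfonyl and hydrogen on the amine nitrogen in the ring cannot be told apart. This limits the reading offered by the first pair: a group on that nitrogen does not by itself go with the lower number, and compound 3 goes against that idea. At the same time, a 3.2-fold higher number from compound 1 to compound 3 (0.50 log units; beyond the scatter), so compound 1, with isopropyl, stands apart from both compound 2 and compound 3, and among these three compounds the change at this nitrogen separates only isopropyl from the other two groups; nothing shown gives a reason for these steps.

The compounds shown leave open whether the lower number of compound 1 belongs to isopropyl alone or to simple alkyl groups on this nitrogen more widely, a question that a straight propyl group, a cyclopropyl group or a tert-butyl group would address. A straight propyl group would also separate the propyl chain from the sulfonyl link that joins it to the ring nitrogen in compound 3.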